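The source may report more compounds than this note shows. Statements on the series, on what has been measured and on what is new or still open speak of the compounds shown alone.

Of the compounds shown here, three have numbers so far in a functional assay on T98G cells (Homo sapiens) for inhibition, read by MTT assay, with a stated time of 72 h (on this read-out higher numbers stand for weaker inhibition and lower numbers for stronger inhibition), as the read-out. Compound 1 (`COc1ccc(NC(=S)NC2CC(C)(C)Oc3ccc(Br)cc32)cc1`) gives 33000 nM and compound 3 (`CC1(C)CC(NC(=O)Nc2ccc(Cl)cc2)c2cc(F)ccc2O1`) gives 30000 nM in this assay as well. Compound 2 (`CC1(C)CC(NC(=S)Nc2ccc([N+](=O)[O-])cc2)c2cc(Br)ccc2O1`) gives 5000 nM there, the lowest of the three numbers, and its gaps to both others lie beyond the scatter.

The next entry is compound 4 (`CC1(C)CC(NC(=S)Nc2ccc([N+](=O)[O-])cc2)c2cc(Cl)ccc2O1`), not yet measured. Its change from compound 2 is chloro in place of bromo on an aromatic carbon, and the place is on a six-membered aromatic ring of carbon only, part of a fused system of two rings.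

Going by the values given here, the only measured single-place step is a 6.6-fold lower number from compound 1 to compound 2 (0.82 log units; beyond the scatter) (nitro in place of methoxy). It is modest and beyond the scatter, but it concerns a different group and leaves the bromo untouched, so it offers no direct guide here. Compound 3 differs from compound 2 in more than one place and isolates nothing. No halogen exchange has been measured on its own.

The expectation in this assay is therefore no step beyond the scatter, in either direction. The estimated step is a 1.2-fold higher number from compound 2 to compound 4 (0.08 log units; within the scatter) as a working figure. For compound 4 the expected value is 6000 nM with an estimated range from 2500 nM to 15000 nM around it.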

Compound 4, half-maximal inhibitory concentration: 4000 nM
Compound 4: the middle estimate sits 1.5-fold (0.18 log units) above what was measured; measured number inside the range.
By their numbers in this assay, from the lowest: compounds 4 and 2 (each within the scatter of the next); then compounds 3 and 1 (each within the scatter of the next).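

In this assay, going by these compounds alone, chloro in place of bromo on the aromatic carbon gives a 1.3-fold lower number from compound 2 to compound 4 (0.10 log units; within the scatter), the first halogen exchange that can be read on its own. Within the data shown here, with the nitro group kept, this position therefore takes either bromo or chloro without a step beyond the scatter, whereas the only step beyond the scatter so far remains a 6.6-fold lower number from compound 1 to compound 2 (0.82 log units; beyond the scatter), at the place where nitro replaces methoxy. No supporting data bear on this result, so the compounds give no explanation for the similar numbers of compound 2 and compound 4.

Among these compounds, still open is whether this position stays as undemanding for groups unlike the halogens, such as an amine, a nitrile or a carboxylic acid, since bromo and chloro are the only groups compared here in a single-place step. Also open, on these data alone, is whether the same exchange gives a similar result with methoxy in place of nitro, and fluoro at this position cannot be judged from compound 3, which differs from compound 2 in more than one place.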